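Swapping a Halogenated Phenyl for a Free Acrylic Acid

This account rests on a few compounds, and the source may have more. Where it says the series, first, only, none or still open, it means among the compounds named here.

Compound 1 `COC(=O)/C=C/c1cccc(N(Cc2ccc(-c3ccc(F)c(Cl)c3)cc2)C(=O)C2CCCCC2)c1`: 66 nM
Compound 2 `COC(=O)/C=C/c1cccc(N(Cc2ccc(/C=C/C(=O)OC(C)(C)C)cc2OCc2ccccc2)C(=O)C2CCCCC2)c1`: > 1000 nM

Of the compounds shown here, two on a shared core have been tested in an assay on isolated protein with Bile acid receptor (Homo sapiens) as the target; on this read-out higher numbers stand for an effect only at larger amounts of compound and lower numbers for an effect already at smaller amounts. In this assay, among the measured compounds shown here, compound 1 gives 66 nM, and it is the only compound with a true number. For compound 2 the read-out is a limit of the assay rather than a number, namely > 1000 nM. Put another way, (the limit of > 1000 nM in this assay, at which 1 of the 2 values shown sits), so compound 1 stands alone as the only measured point.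

Compound 3 `COC(=O)/C=C/c1cccc(N(Cc2ccc(/C=C/C(=O)O)cc2)C(=O)C2CCCCC2)c1` is not yet measured. It differs from compound 1 at one spot on the outer ring: 2-carboxyethenyl in place of 3-chloro-4-fluorophenyl on an aromatic carbon. For the measured compounds named here, no pair of measured compounds separated by a single change is available, so this step has no direct precedent. The step is nevertheless expected to weaken binding well beyond the usual scatter, and the estimated change from compound 1 to compound 3 is a 23-fold higher number from compound 1 to compound 3 (1.36 log units; beyond the scatter). Compound 3 is therefore estimated at 1500 nM, with an expected range from 300 nM to 8000 nM.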

Compound 3, half-maximal effective concentration: > 1000 nM
Compound 3: no number, only a limit; the forecaster's own chance of this, stated with the estimate: 55%; the middle value does not contradict the limit.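

In this assay, among the compounds shown here, putting 2-carboxyethenyl in place of 3-chloro-4-fluorophenyl gives an at least 15-fold higher number from compound 1 to compound 3 (1.18 log units; beyond the scatter), the only single change on the shared core that can be read so far. This shows that binding depends strongly on the group at this aromatic carbon, which compound 2 could not show, as it differs from compound 1 in more than one place. The step rests on a limit of the assay rather than a number for compound 3, so its full size stays unknown: the limit of > 1000 nM in this assay, at which 2 of the 3 values shown sit.

The compounds shown leave open whether the loss goes with the removal of the aromatic ring or with the arrival of the carboxylic acid, as both happen in this one change. An unsubstituted phenyl or a methyl ester at this position would help to tell the two apart.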